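The source may hold more compounds than are shown below. What is called first, only, known or untested is meant among the compounds shown, and "the series" means these compounds.

Measured compounds in a functional assay on HEK293 cells for antagonist activity at metabotropic glutamate receptor 5 (Homo sapiens), read by FLIPR and calcium flux; on this read-out lower numbers stand for stronger inhibition and higher numbers for weaker inhibition:
compound 1 `COc1ccc(C(=O)N[C@H]2CCC[C@H](NC(=O)c3cccc(Cl)c3)C2)cc1` gives 266 nM
compound 2 `CN(C)c1ccc(C(=O)N[C@H]2CCC[C@H](NC(=O)c3cccc(Cl)c3)C2)cc1` gives 473 nM
compound 3 `O=C(N[C@H]1CCC[C@H](NC(=O)c2cnccn2)C1)c1cccc(Cl)c1` gives 1370 nM

Compound 2 holds the second highest number of the three in this assay. The step of a 1.8-fold higher number from compound 1 to compound 2 (0.25 log units; within the scatter) stays within the scatter, so compounds 1 and 2 cannot be told apart on these numbers, whereas the step of a 2.9-fold higher number from compound 2 to compound 3 (0.46 log units; beyond the scatter) lies beyond it.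

Compound 4 `O=C(N[C@H]1CCC[C@H](NC(=O)C2CCCCC2)C1)c1cccc(Cl)c1` differs from compound 2 in one place: cyclohexyl in place of 4-(dimethylamino)phenyl on a carbonyl carbon. Within the data shown here, the steps that bear on this change are those in which the amide on the same carbonyl carbon was altered: a 5.2-fold higher number from compound 1 to compound 3 (0.71 log units; beyond the scatter) and a 2.9-fold higher number from compound 2 to compound 3 (0.46 log units; beyond the scatter), both modest rises when the substituted phenyl is exchanged for a different ring. Among the measured compounds shown here, no measured step exchanges an aromatic ring for a saturated one, so the pyrazinyl case is the only guide, and it points to a higher number. The expectation for compound 4 in this assay is therefore a modest rise, a 2.3-fold higher number from compound 2 to compound 4 (0.37 log units; beyond the scatter), with wide uncertainty since the ring type is new to the series. Compound 4 is estimated at 1100 nM, within a range from 350 nM to 3500 nM.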

Compound 4, half-maximal inhibitory concentration: 857 nM
Compound 4: the middle estimate sits 1.3-fold (0.11 log units) above what was measured; the measured number falls inside the stated range.
By their numbers in this assay, from the lowest: compounds 1, 2, 4 and 3 (each within the scatter of the next, the first and the last beyond it).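

In this assay, a saturated ring on this carbonyl carbon gives a number that cannot be separated from those of the aromatic rings in two of the three comparisons: cyclohexyl in place of 4-(dimethylamino)phenyl gives a 1.8-fold higher number from compound 2 to compound 4 (0.26 log units; within the scatter) and cyclohexyl in place of pyrazin-2-yl gives a 1.6-fold lower number from compound 3 to compound 4 (0.20 log units; within the scatter) in the same assay. Only the comparison with 4-methoxyphenyl separates the two groups, with a 3.2-fold higher number from compound 1 to compound 4 (0.51 log units; beyond the scatter) as a modest step beyond the scatter, so an aromatic ring at this position is not required for activity in the range spanned by the series, although the lowest number shown still belongs to an aromatic group. Nothing available on these compounds accounts for how little the change from aromatic to saturated ring moves the number here.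

Still open, going by these compounds, is whether a cyclopentyl ring, an open butyl chain or a piperidine ring on the same carbonyl carbon would stay in this range. Also open, on these data alone, is whether a methoxy group or an amine carried on the cyclohexyl ring would bring the number closer to that of compound 1 at 266 nM or move it further away.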